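Chloro in Place of Cyano: Expected Cytotoxicity of Compound 4

The compounds below may be only part of what the source reports. "The series", "measured", "known", "first", "only" and "open" are said of these compounds alone.

The measured compounds are these. Compound 1 `C/C(=C\c1cc(-c2ccc(C)nc2)co1)C(N)=O`: in a functional assay on HeLa cells (Homo sapiens) for cytotoxicity, read by CCK-8 assay, with a stated time of 24 h (on this read-out lower numbers stand for stronger inhibition and higher numbers for weaker inhibition), compound 1 gives > 50000 nM, which is a limit of the assay rather than a number. Compound 2 `C/C(=C\c1cc(-c2ccc(F)cc2)cs1)C(N)=O`: compound 2 gives 20800 nM. Compound 3 `C/C(=C\c1cc(-c2ccc(C#N)cc2)cs1)C(N)=O`: compound 3 gives 250 nM.

Among the two actual numbers, compound 3 stands lowest, and its nearest neighbour is compound 2, separated by the step of an 83-fold lower number from compound 2 to compound 3 (1.92 log units; beyond the scatter). Compound 1 sits at the limit of > 50000 nM in this assay, at which 1 of the 3 values shown sits, and offers no number to compare.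

Compound 4 `C/C(=C\c1cc(-c2ccc(Cl)cc2)cs1)C(N)=O` differs from compound 3 in one place: chloro in place of cyano on an aromatic carbon. For the measured compounds named here, only one measured step touches this position, the step of an 83-fold lower number from compound 2 to compound 3 (1.92 log units; beyond the scatter), where a cyano group arriving in place of fluoro brought a very large fall in the number. Compound 4 removes the cyano again, but brings in chloro rather than fluoro, so a direct read-across is not available. The expectation is that the number rises clearly, by roughly a 20-fold higher number from compound 3 to compound 4 (1.30 log units; beyond the scatter), a step beyond the scatter but likely smaller than the measured one. Compound 4 is therefore expected to give about 5000 nM, with a range from 800 nM to 30000 nM.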

Compound 4, half-maximal inhibitory concentration: > 50000 nM
Compound 4 ended at the assay's limit; the forecaster's own chance of this, stated with the estimate: 10%; at least 10-fold (1.00 log units) between middle value and limit.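

In this assay, putting chloro on this aromatic carbon in place of cyano gives an at least 200-fold higher number from compound 3 to compound 4 (2.30 log units; beyond the scatter), so the low number of compound 3 now stands apart from two halogen compounds rather than one, and the earlier contrast was not peculiar to fluoro. Swapping one halogen for the other also matters, since chloro in place of fluoro gives an at least 2.4-fold higher number from compound 2 to compound 4 (0.38 log units; beyond the scatter), which means chloro recovers none of what is lost when cyano leaves. The result for compound 4 is a limit of the assay and not a number, so both steps give only a minimum size: the limit of > 50000 nM in this assay, at which 2 of the 4 values shown sit.

The compounds shown leave open whether a low number at this position belongs to cyano alone or could also come with other groups, such as an amine, a carboxylic acid or a methoxy group. They also leave open how far compound 4 lies beyond the limit, and whether cyano would have a similar effect on a different core, since compound 1 differs from these compounds in more than one place.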